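The compounds below may be only part of what the source reports. "The series", "measured", "known", "first", "only" and "open" are said of these compounds alone.

Compound 3 `Cc1ccc(CC2CCN(c3nc(C(F)(F)F)ccc3CNC(=O)C(C)c3ccc(NS(C)(=O)=O)c(F)c3)CC2)cc1` gives the lowest number of the three measured compounds in a functional assay on CHO-K1 cells for antagonist activity at transient receptor potential cation channel subfamily V member 1 (Homo sapiens), read by FLIPR (on this read-out lower numbers stand for stronger inhibition and higher numbers for weaker inhibition), at 0.2 nM. Compound 2 `CC(C(=O)NCc1ccc(C(F)(F)F)nc1N1CCC(c2ccccc2)CC1)c1ccc(NS(C)(=O)=O)c(F)c1` gives 0.6 nM, and compound 1 `CC(C(=O)NCc1ccc(C(F)(F)F)nc1N1CCCCC1C)c1ccc(NS(C)(=O)=O)c(F)c1` gives 2.9 nM. Compound 4 `CCCCOC1CCN(c2nc(C(F)(F)F)ccc2CNC(=O)C(C)c2ccc(NS(C)(=O)=O)c(F)c2)CC1` differs from compound 3 by butoxy in place of 4-methylbenzyl on a saturated ring carbon. Within the data shown here, two measured steps bear on the same saturated ring carbon: a 4.8-fold lower number from compound 1 to compound 2 (0.68 log units; beyond the scatter) and a 3.0-fold lower number from compound 2 to compound 3 (0.48 log units; beyond the scatter), both gains when an aromatic group was placed there or enlarged. Compound 4 removes that aromatic group and puts a butoxy chain in its place, so the gains of those two steps are expected to be partly undone, an estimated 10-fold higher number from compound 3 to compound 4 (1.00 log units; beyond the scatter). Compound 4 is therefore expected to give about 2 nM in this assay, within 0.5 nM to 8 nM.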

Compound 4, inhibition constant: 3.5 nM
Compound 4: the middle estimate sits 1.8-fold (0.24 log units) below what was measured, and the stated range covers the measured number.
By their numbers in this assay, from the lowest: compound 3; then compound 2; then compounds 1 and 4 (each within the scatter of the next).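

The ring-free butoxy group on this saturated ring carbon gives higher numbers than either aromatic group (an 18-fold higher number from compound 3 to compound 4 (1.24 log units; beyond the scatter)) and (a 5.8-fold higher number from compound 2 to compound 4 (0.77 log units; beyond the scatter)), so here the lower numbers go with the carbon-only aromatic ring of compound 2 and compound 3. Compound 4 also stays within the scatter of compound 1, which has a different group on the aromatic carbon (a 1.2-fold higher number from compound 1 to compound 4 (0.08 log units; within the scatter)). No measurement shown explains these differences. The compounds shown leave open whether the entering oxygen or the lost ring counts more, and a pentyl chain or a benzyloxy group on this carbon would bear on that.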